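The compounds below may be only part of what the source reports. "The series", "measured", "known", "first", "only" and "open" are said of these compounds alone.

Measured so far in an ADME assay on MCF7-DOX cells (Homo sapiens) for cytotoxicity, read by MTT assay, with a stated time of 48 h; on this read-out higher numbers stand for weaker inhibition and lower numbers for stronger inhibition:

Compound 1, `COc1cc(OC)c(C(=O)/C=C/c2ccc(N(C)C)cc2)c(O)c1CC=C(C)C`, gives > 100000 nM, which is a limit of the assay rather than a number.
Compound 2, `COc1cc(OC)c(C(=O)/C=C/c2cccc(N3CCNCC3)c2)c(O)c1C`, gives 98700 nM.
Compound 3, `CCc1c(OC)cc(OC)c(C(=O)/C=C/c2cccc(N3CCNCC3)c2)c1O`, gives > 100000 nM, again a limit of the assay and not a number.

Compound 1 therefore stands at the edge of what this assay can report; its value is a limit only. That limit is the one at which two of the three values sit (the limit of > 100000 nM in this assay, at which 2 of the 3 values shown sit). Going by the values given here, the only step measured between two compounds is an at least 1.0-fold higher number from compound 2 to compound 3 (0.00 log units; that floor lies within the scatter), where the change is methyl in place of hydrogen on a saturated chain carbon bound to an aromatic carbon; that step lies within the scatter and touches a different part of the shared core.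

Compound 4, `COc1cc(OC)c(C(=O)/C=C/c2cccc(F)c2)c(O)c1CC=C(C)C`, differs from compound 1 as follows: 3-fluorophenyl in place of 4-(dimethylamino)phenyl on a double-bonded chain carbon bound to a double-bonded chain carbon. Among the compounds with values here, no measured step involves this change, so there is nothing among the measured compounds that speaks for a move in either direction; the one measured step was flat, and compound 1 itself sits at the limit.

Compound 4 is therefore expected to stay around the same region, with a step of a number no higher from compound 1 to compound 4 (the limit leaves the size open), and its value in this assay is estimated at 100000 nM within a range from 30000 nM to 300000 nM.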

Compound 4, half-maximal inhibitory concentration: 45400 nM
Compound 4: the middle estimate sits 2.2-fold (0.34 log units) above what was measured, and the stated range covers the measured number.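

In this assay the change on a double-bonded chain carbon bound to a double-bonded chain carbon, 3-fluorophenyl in place of 4-(dimethylamino)phenyl, brings an at least 2.2-fold lower number from compound 1 to compound 4 (0.34 log units; beyond the scatter) and so moves the read-out towards stronger inhibition by more than the usual scatter. Going by these compounds alone, compound 4 gives 45400 nM as a true number, which shows that the aromatic group at this place can shift the read-out, whereas the one earlier step, in a different part of the shared core, stayed within the scatter. Compound 1 gives > 100000 nM as a limit of the assay and not a number, so the step is only a floor, and its full size stays unknown because compound 1 sits at that limit: the limit of > 100000 nM in this assay, at which 2 of the 4 values shown sit.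

The change removes the dimethylamino group, adds a fluorine and alters where the substituent sits on the ring, all at once, so these compounds cannot show which of these matters. As far as these compounds go, a plain phenyl group, 4-fluorophenyl or 3-(dimethylamino)phenyl at this place would help separate those parts, and whether the step holds on the other variants of the shared core remains open.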